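A Longer Alkyl Chain on an Inactive Anticonvulsant Core

This account rests on a few compounds, and the source may have more. Where it says the series, first, only, none or still open, it means among the compounds named here.

Three compounds sharing one core were tested in a functional assay on the whole organism (strain C57B/6) with Mus musculus as the target, in the maximal electroshock model; on this read-out lower numbers stand for an effect already at smaller amounts and higher numbers for an effect only at larger amounts of compound. Compound 1 `CCc1nncn1-c1ccc(OCc2ccccc2F)cc1` gives 21.2 mg/kg, and compound 2 `CCc1nncn1-c1ccc(OCc2ccc(Cl)cc2)cc1` gives 19.7 mg/kg; the step of a 1.1-fold lower number from compound 1 to compound 2 (0.03 log units; within the scatter) is small. Compound 3 `CCCCOc1ccc(-n2cnnc2CC)cc1` reaches only the limit > 100 mg/kg, so no number is known for it. The steps of an at least 4.7-fold higher number from compound 1 to compound 3 (0.67 log units; beyond the scatter) and an at least 5.0-fold higher number from compound 2 to compound 3 (0.70 log units; beyond the scatter) show that a propyl in place of either aryl group pushed the value to the limit (the limit of > 100 mg/kg in this assay, at which 1 of the 3 values shown sits). Compound 4 `CCCCCCCCCCCCOc1ccc(-n2cnnc2CC)cc1` differs from compound 3 by octyl in place of hydrogen on a saturated chain carbon, four bonds along the chain from an oxygen on an aromatic ring. For the measured compounds named here, no measured step covers lengthening such a chain, so the change is expected to be a step that the limit leaves unreadable from compound 3 to compound 4. Compound 4 is therefore estimated at 150 mg/kg, within 40 mg/kg to 500 mg/kg, with a limit again likely.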

Compound 4, dose for half-maximal effect: > 100 mg/kg
Compound 4 was reported as a limit; the forecaster's own chance of this, stated with the estimate: 70%; the middle value lies beyond the limit too.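

Compound 3 and compound 4 both stand at a limit rather than a number, so no step between them can be read: the limit of > 100 mg/kg in this assay, at which 2 of the 4 values shown sit.

The compounds shown leave open whether octyl in place of hydrogen changes the effect at all.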